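This account rests on a few compounds, and the source may have more. Where it says the series, first, only, none or still open, it means among the compounds named here.

Compound 1 `CCN1CCN(c2cccc3c2CN([C@H](CCCNC(=O)c2c(C)n[nH]c2C)c2ccc(OC)c(OC)c2)C3=O)CC1`: 11 nM
Compound 2 `COc1ccc([C@@H](CCCN(C)S(=O)(=O)c2cccs2)N2Cc3c(cccc3N3CCN(C4CCC4)CC3)C2=O)cc1OC`: 44 nM

Within the data shown here, in an assay on RMS13 cells for displacement of a labelled ligand from Urotensin-2 receptor (Homo sapiens), read by scintillation proximity assay (a lower number here means a stronger inhibitor, a higher number a weaker inhibitor), compound 2 gives 44 nM, the higher of the two numbers measured so far. Compound 1 gives 11 nM, a lower number whose gap to compound 2 lies beyond the usual scatter. Compound 3 `COc1ccc([C@@H](CCCN(C)S(=O)(=O)c2cccs2)N2Cc3c(cccc3N3CCN(C4CC4)CC3)C2=O)cc1OC` differs from compound 2 only by cyclopropyl in place of cyclobutyl on an amine nitrogen in a ring. Among the measured compounds shown here, no pair of measured compounds shows a step of this kind, so nothing measured tells its size. Compound 3 is expected to stay close to compound 2, the step of a 1.1-fold higher number from compound 2 to compound 3 (0.06 log units; within the scatter) being expected to remain within the scatter in either direction. Compound 3 is estimated at 50 nM, with a range from 20 nM to 130 nM.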

Compound 3, inhibition constant: 59 nM
Compound 3: the middle estimate sits 1.2-fold (0.07 log units) below what was measured; measured number inside the range.
By their numbers in this assay, from the lowest: compound 1; then compounds 2 and 3 (each within the scatter of the next).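

In this assay, cyclopropyl in place of cyclobutyl on the amine nitrogen in the ring gives a 1.3-fold higher number from compound 2 to compound 3 (0.13 log units; within the scatter) and leaves the two compounds indistinguishable. Among these compounds, this is the first measured step at this position, and it shows that one carbon fewer in this small ring does not move the number beyond the scatter. No outside measurement bears on this result. Going by these compounds, whether a larger group on this nitrogen, such as cyclohexyl or benzyl, would read the same remains open, as does the effect of an acetyl group there.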